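Cytotoxicity on Vero Cells: Pyridinyl Amide to Phenyl Amide

A few compounds are considered here, and "the series" means these few. Any claim that something is new, unique, unknown or untested is made for them only; others in the source may bear on it.

Measured compounds:
compound 1 `COc1ccc(-n2c(SC(C)C(=O)Nc3nc(C)c(Br)cc3Br)nc3ccccc32)cc1`: 9700 nM
compound 2 `COc1ccc(-n2c(SC(C)C(=O)Nc3nc(C)cc(Cl)n3)nc3ccccc32)cc1`: "not determined" (no result reported)
compound 3 `COc1ccc(-n2c(SC(C)C(=O)Nc3nc(C)cs3)nc3ccccc32)cc1`: "not determined" (no result reported)

In an ADME assay on Vero cells (Chlorocebus sabaeus) for cytotoxicity, read by MTT assay, with a stated time of 24 h (a lower number here means that less compound is tolerated, a higher number that more compound is tolerated), compound 1 gives 9700 nM. Going by the values given here, this is the only number in the set, since compound 2 gives "not determined" (no result reported) and compound 3 gives "not determined" (no result reported) in this assay, so compound 1 stands alone and cannot be ranked against them. Compound 4 `COc1ccc(-n2c(SC(C)C(=O)Nc3ccc(C)cc3Cl)nc3ccccc32)cc1` differs from compound 1 by 2-chloro-4-methylphenyl in place of 3,5-dibromo-6-methylpyridin-2-yl on an amide-type nitrogen. Among the compounds with values here, no step between two measured compounds is available here, so the data give no hint of how this change moves the tolerated concentration. The step of a 1.1-fold higher number from compound 1 to compound 4 (0.05 log units; within the scatter) is expected to stay within the usual scatter, with no clear direction. Compound 4 is therefore estimated at 11000 nM, with a range from 4000 nM to 35000 nM.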

Compound 4, half-maximal cytotoxic concentration: > 75000 nM
Compound 4 gave a limit, no number; the forecaster's own chance of this, stated with the estimate: 25%; at least 6.8-fold (0.83 log units) between middle value and limit.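

In this assay, the group on the amide-type nitrogen proves able to move the tolerated concentration: 2-chloro-4-methylphenyl in place of 3,5-dibromo-6-methylpyridin-2-yl gives an at least 7.7-fold higher number from compound 1 to compound 4 (0.88 log units; beyond the scatter). For compound 4 the result is a limit of the assay and not a number: the limit of > 75000 nM in this assay, at which 1 of the 4 values shown sits. From the compounds shown here alone, the full size of the step therefore remains unknown.

Going by these compounds, the ring nitrogen and the halogens change together, so it stays open which of them carries the step. On these data alone, how an amine or a carboxylic acid in place of the chlorine would read in this assay also stays open.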